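Moving the chlorine on the pendant ring of compound 1

A few compounds are considered here, and "the series" means these few. Any claim that something is new, unique, unknown or untested is made for them only; others in the source may bear on it.

Compound 1 `O=C1/C(=C\c2ccccc2Cl)c2ccccc2N1c1c(Cl)cccc1Cl` was tested in a functional assay on MIA PaCa-2 cells (Homo sapiens) for cytotoxicity, read by MTT assay, with a stated time of 72 h; a higher number here means that more compound is needed for the effect, a lower number that less compound is needed. In this assay compound 1 gives only a limit, > 100 ug/mL, so no single number is known for it; this is the limit of > 100 ug/mL in this assay, at which 1 of the 3 values shown sits. Compound 2 `O=C1/C(=C\c2cc3ccccc3nc2Cl)c2ccccc2N1c1c(Cl)cccc1Cl` carries a different pendant ring and gives 5 ug/mL in this assay. Compound 3 `Cc1ccc2nc(Cl)c(/C=C3\C(=O)N(c4c(Cl)cccc4Cl)c4ccccc43)cc2c1C` has "not determined" (no result reported) in this assay, so it adds nothing to the comparison. Compound 4 `O=C1/C(=C\c2cccc(Cl)c2)c2ccccc2N1c1c(Cl)cccc1Cl` differs from compound 1 by one change: 3-chlorophenyl in place of 2-chlorophenyl on a double-bonded chain carbon bound to a double-bonded ring carbon. For the measured compounds named here, no measured step of this kind exists to lean on. The step from compound 1 to compound 4 is expected to be small, a number no higher from compound 1 to compound 4 (the limit leaves the size open), not beyond the scatter. Compound 4 is therefore estimated at 100 ug/mL, between 40 ug/mL and 200 ug/mL, with a fair chance that only a limit is again reported.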

Compound 4, concentration for half-maximal effect: 5 ug/mL
Compound 4: middle estimate off by 20-fold (1.30 log units), on the high side; the whole stated range lies above it.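

In this assay, shifting one chlorine, with the same atoms and the same counts of donors and acceptors, gives an at least 20-fold lower number from compound 1 to compound 4 (1.30 log units; beyond the scatter). The place of this chlorine on the pendant ring therefore matters in its own right, something compound 1 and compound 2 could not show, as they differ in the whole ring. The true step may be larger, because compound 1 is known only as a limit: the limit of > 100 ug/mL in this assay, at which 1 of the 4 values shown sits.

Going by these compounds, whether the chlorine itself is needed remains open. A plain phenyl group, or an amine or methoxy group in place of the chlorine of the 3-chlorophenyl group, would address this.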